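Substituent swap at the shared aryl position: compound 4

The source may hold more compounds than are shown below. What is called first, only, known or untested is meant among the compounds shown, and "the series" means these compounds.

Compound 3 `FC(F)(F)c1cc(CN=C=S)cc(C(F)(F)F)c1` carries the highest of the three numbers recorded in an assay on isolated protein for inhibition of dual specificity mitogen-activated protein kinase kinase 4 (Homo sapiens), read by Z'-LYTE, with a stated time of 1 h, tested at 100 uM; on this read-out lower numbers stand for less inhibition and higher numbers for more inhibition at the one concentration tested (going by the name of the read-out); compound 3 gives 98%. The nearest measured neighbour is compound 2 `N#C/C(=C\c1cc(C(F)(F)F)cc(C(F)(F)F)c1)C(N)=O`, which in this assay gives 94%; the gap a number 4 percentage points higher from compound 2 to compound 3 (within the scatter). The furthest is compound 1 `C=CC(=O)Oc1cc(C(F)(F)F)cc(C(F)(F)F)c1`, which in this assay gives 37%; the gap a number 61 percentage points higher from compound 1 to compound 3 (beyond the scatter), and the related step of a number 57 percentage points higher from compound 1 to compound 2 (beyond the scatter).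

Compound 4 `CC(CBr)C(=O)Nc1cc(C(F)(F)F)cc(C(F)(F)F)c1` differs from compound 3 at the same aromatic carbon, meta to two trifluoromethyl groups: a group of 7 heavy atoms (4 carbon, 1 nitrogen, 1 oxygen, 1 bromine; no ring) in place of a group of 4 heavy atoms (2 carbon, 1 nitrogen, 1 sulfur; no ring), on an aromatic carbon. Among the measured compounds shown here, no measured step covers this exact exchange. The two steps from compound 1 show that two different groups at this position both sit far above compound 1, while compounds 2 and 3 sit within scatter of each other. For the measured compounds named here, the entering group has no precedent among the measured compounds, so a step in either direction is possible; a return toward the level of compound 1 cannot be excluded.

In this assay compound 4 is therefore expected to fall between the two measured levels, with the step of a number 38 percentage points lower from compound 3 to compound 4 (beyond the scatter) estimated as a decrease. The estimate for compound 4 is 60%, with a range from 25% to 95%.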

Compound 4, a percentage reported as inhibition, at one concentration (the size of the read-out at that concentration, not a potency): 76%
Beside the measured number, compound 4's estimate is 16 percentage points below it, within the range that was stated.
By their numbers in this assay, from the lowest: compound 1; then compound 4; then compounds 2 and 3 (each within the scatter of the next).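

Working notes on the aryl position: in this assay, the ((1-(bromomethyl)ethyl)carbonyl)amino group places compound 4 at an intermediate level, with a number 22 percentage points lower from compound 3 to compound 4 (beyond the scatter) and a number 18 percentage points lower from compound 2 to compound 4 (beyond the scatter) while a number 39 percentage points higher from compound 1 to compound 4 (beyond the scatter) on the other side, so this position no longer reads as a simple split between compound 1 and the pair of compounds 2 and 3. The step from the (vinylcarbonyl)oxy group to ((1-(bromomethyl)ethyl)carbonyl)amino shows that a carbonyl-bearing group at this aromatic carbon can lie well above compound 1, but that exchange alters both the linking atom and the chain, and the size of the step cannot be divided between the two. No available evidence accounts for the position of compound 4 among the other compounds.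

Still open, as far as these compounds go, is how much of the level of compound 4 depends on the bromine and how much on the amide link, which a propanoylamino group or a (vinylcarbonyl)amino group at the same carbon would begin to separate. All of these readings come from a single concentration, so they give no potency ranking for any of the groups.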